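Halogen swap on the aryl triazole of a sulfonamide

The compounds below may be only part of what the source reports. "The series", "measured", "known", "first", "only" and "open" are said of these compounds alone.

Compound 3 `O=c1[nH]cc(S(=O)(=O)Nc2ccc(-c3cn(-c4ccc(F)cc4)nn3)cc2)c(=O)[nH]1` is one of three close relatives examined in an ADME assay on GES1 cells (Homo sapiens) for cytotoxicity, read by MTT assay, with a stated time of 24 h; on this read-out higher numbers stand for lower toxicity in this test and lower numbers for higher toxicity in this test. Compound 1 `O=c1[nH]cc(S(=O)(=O)Nc2ccc(-c3cn(-c4ccccc4)nn3)cc2)c(=O)[nH]1` is recorded in this assay as "not toxic" (no number reported), and compound 2 `Cc1ccc(-n2cc(-c3ccc(NS(=O)(=O)c4c[nH]c(=O)[nH]c4=O)cc3)nn2)cc1` likewise as "not toxic" (no number reported). For compound 3 the read-out in this assay is given only as a limit of the test, > 100000 nM. Compound 3 thus stands where the single entry with a figure stands, namely at the limit of > 100000 nM in this assay, at which 1 of the 3 values shown sits, and the two companions bring no number against which it could be ranked.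

Compound 4 `O=c1[nH]cc(S(=O)(=O)Nc2ccc(-c3cn(-c4ccccc4Cl)nn3)cc2)c(=O)[nH]1` differs from compound 3 in a single spot: 2-chlorophenyl in place of 4-fluorophenyl on an aromatic nitrogen. For the measured compounds named here, no step between two measured compounds in this set carries a number, so the size of this change cannot be read from a measured pair. What the three measured compounds do show, whatever aryl group sits on the ring nitrogen, is an absence of toxicity in this assay.

The expectation for compound 4 is accordingly no movement beyond the scatter, an estimated step that the limit leaves unreadable from compound 3 to compound 4. Compound 4 is expected to read 150000 nM in this assay, within a range from 50000 nM to 500000 nM, and most probably once more as a limit rather than a figure.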

Compound 4, half-maximal cytotoxic concentration: 16400 nM
Estimate against measurement, compound 4: 9.1-fold (0.96 log units) above; measured number below the stated range.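

In this assay, the change to 2-chlorophenyl in place of 4-fluorophenyl on the aromatic nitrogen gives an at least 6.0-fold lower number from compound 3 to compound 4 (0.78 log units; beyond the scatter), so the aryl group at this position can move the read-out towards higher toxicity in this test. The earlier compounds shown here carried different aryl groups here without yielding any figure that could be ranked, whereas compound 4 gives the first figure in the set that is not a limit. The size of the step remains a minimum, not an exact difference, since the value for compound 3 is only a limit of the test: the limit of > 100000 nM in this assay, at which 1 of the 4 values shown sits.

The steps to compound 4 from compound 1 and compound 2 cannot be read, since neither carries a number, and the single swap changes both the halogen and its place on the phenyl ring, so the compounds shown do not tell which of the two matters. Also open, from the compounds shown here alone, is how the read-out would respond to a phenyl group carrying an amine or a carboxylic acid on the same nitrogen.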